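A few compounds are considered here, and "the series" means these few. Any claim that something is new, unique, unknown or untested is made for them only; others in the source may bear on it.

In a physicochemical assay for solubility (on this read-out higher numbers stand for higher solubility and lower numbers for lower solubility), three compounds sharing one core have been measured: compound 1 `O=C(c1ccc(Cl)cc1)N1CCC(NS(=O)(=O)c2cc(S(=O)(=O)c3ccccc3)ccc2C(F)(F)F)CC1` gives 3100 nM, compound 2 `O=C(c1ccccn1)N1CCC(NS(=O)(=O)c2cc(S(=O)(=O)c3ccccc3)ccc2C(F)(F)F)CC1` gives 100000 nM, and compound 3 `CC(C)(C)OC(=O)N1CCC[C@H]1C(=O)N1CCC(NS(=O)(=O)c2cc(S(=O)(=O)c3ccccc3)ccc2C(F)(F)F)CC1` gives 25000 nM, the second highest of the three. Compound 4 `CC(C)(C)OC(=O)N1CC[C@H](C(=O)N2CCC(NS(=O)(=O)c3cc(S(=O)(=O)c4ccccc4)ccc3C(F)(F)F)CC2)C1` has the same atoms as compound 3, joined differently: 1-(tert-butoxycarbonyl)pyrrolidin-3-yl replaces 1-(tert-butoxycarbonyl)pyrrolidin-2-yl on a carbonyl carbon (1-(tert-butoxycarbonyl)pyrrolidin-3-yl in place of 1-(tert-butoxycarbonyl)pyrrolidin-2-yl on a carbonyl carbon). Three measured steps change this same place: a 32-fold higher number from compound 1 to compound 2 (1.51 log units; beyond the scatter), an 8.1-fold higher number from compound 1 to compound 3 (0.91 log units; beyond the scatter) and a 4.0-fold lower number from compound 2 to compound 3 (0.60 log units; beyond the scatter). All lie beyond the scatter, but each exchanges different atoms, so none directly matches this rearrangement. No change beyond the scatter is therefore expected, and the expected size is no change at the digits printed from compound 3 to compound 4 (within the scatter). Compound 4 is estimated at 25000 nM, with an expected range from 9000 nM to 70000 nM.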

Compound 4, solubility: 25000 nM
The estimate for compound 4 equals the measured number at the digits printed, within the range that was stated.
By their numbers in this assay, from the lowest: compound 1; then compounds 3 and 4 (each within the scatter of the next); then compound 2.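

In this assay, putting 1-(tert-butoxycarbonyl)pyrrolidin-3-yl in place of 1-(tert-butoxycarbonyl)pyrrolidin-2-yl on the carbonyl carbon gives no change at the digits printed from compound 3 to compound 4 (within the scatter) for this pair, the first direct test of moving the attachment point at this position. Compound 4 therefore stands where compound 3 does against the other two, with a 4.0-fold lower number from compound 2 to compound 4 (0.60 log units; beyond the scatter) and an 8.1-fold higher number from compound 1 to compound 4 (0.91 log units; beyond the scatter) as its steps. No measured evidence here explains this result.

As far as these compounds go, whether the attachment point matters as little for other groups remains open. A pyridin-3-yl group, or the pyrrolidine with a free amine in place of the tert-butoxycarbonyl group, could answer this.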